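Swapping thiazole for oxazole in a lactam series

This account rests on a few compounds, and the source may have more. Where it says the series, first, only, none or still open, it means among the compounds named here.

Of the compounds shown here, two in this set have been tested in an ADME assay on microsomes from liver (Homo sapiens) for metabolic stability; a higher number here means faster removal of the compound, a lower number slower removal. Compound 1, with the structure `Cc1cc2c(cc1Cc1ccc(-c3cocn3)cc1)C(=O)N([C@H]1CCOC[C@@H]1O)C2`, returns only a limit of the assay: in this assay compound 1 gives < 8 mL/min/kg. Going by the values given here, compound 2, with the structure `Cc1cc2c(cc1Cc1ccc(-c3cscn3)cc1)C(=O)N([C@H]1CCOC[C@@H]1O)CC2`, is the one compound with a full number, and in this assay compound 2 gives 25 mL/min/kg. Among the compounds with values here, it therefore stands as the only measured value, with the other entry sitting at the limit described by the limit of < 8 mL/min/kg in this assay, at which 1 of the 2 values shown sits. Compound 1 and compound 2 differ in more than one place, so the two values show only that one sits at the limit and the other does not.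

Compound 3, with the structure `Cc1cc2c(cc1Cc1ccc(-c3cocn3)cc1)C(=O)N([C@H]1CCOC[C@@H]1O)CC2`, is not yet measured. It differs from compound 2 by 1,3-oxazol-4-yl in place of 1,3-thiazol-4-yl on an aromatic carbon. Within the data shown here, no measured pair shows this exact change. The step from compound 2 to compound 3 is expected to be modest and downward, at a 1.7-fold lower number from compound 2 to compound 3 (0.22 log units; within the scatter), though a result within the scatter would not surprise. Compound 3 is therefore estimated at 15 mL/min/kg, with a range from 6 mL/min/kg to 30 mL/min/kg.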

Compound 3, clearance: 13 mL/min/kg
Compound 3: the middle estimate sits 1.2-fold (0.06 log units) above what was measured, within the range that was stated.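

Going by these compounds alone, the step from 1,3-thiazol-4-yl to 1,3-oxazol-4-yl, on an aromatic carbon para to a large group, is the first change in this set that can be read on its own, and in this assay it gives a 1.9-fold lower number from compound 2 to compound 3 (0.28 log units; within the scatter). Exchanging these two five-membered aromatic rings at this position therefore moves the read-out no further than repeated measurements of one compound would. The earlier compounds shown here could not show this, as they differed in more than one place. Compound 3 also differs in one place from compound 1, in the core, but that step cannot be read: compound 1 gives < 8 mL/min/kg, which is a limit of the assay.

This single pair says nothing about how a quite different group at the same place, such as a simple amine, a carboxylic acid or a plain phenyl ring, would fare in this assay. Whether the swap of the two rings reads the same way on the core of compound 1 also stays open, and the one value there gives no number to work from: the limit of < 8 mL/min/kg in this assay, at which 1 of the 3 values shown sits.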